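Sulfonamide in Place of Amide on a Naphthol Core

The source may report more compounds than this note shows. Statements on the series, on what has been measured and on what is new or still open speak of the compounds shown alone.

The series centres on a shared core bearing a hydroxy group. In an assay on isolated protein for inhibition of histone acetyltransferase KAT2B (Homo sapiens), read by fluorescence, with a stated time of 5 min, in the presence of a further agent that is not named here (a lower number here means a stronger inhibitor, a higher number a weaker inhibitor), compound 1 `Nc1ccc(O)c2ccncc12` gives 7100 nM, while compound 3 `CCCCCCCCCC(=O)Nc1ccc(O)c2ccccc12` gives 160000 nM. Compound 2 `NC(=O)c1ccc(O)c2ccccc12` gives "not determined" (no result reported) in this assay, so its standing cannot be placed between these two. Compound 4 `CS(=O)(=O)Nc1ccc(O)c2ccccc12` is not yet measured; it differs from compound 2 by methanesulfonamido in place of carbamoyl on an aromatic carbon. Among the measured compounds shown here, with no result for compound 2, no step can be drawn from it, and the direction of the change in this assay rests only on the two other compounds, which bracket a broad and weak range. Compound 4 is therefore expected to give 50000 nM, with an estimated range from 10000 nM to 250000 nM.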

Compound 4, half-maximal inhibitory concentration: 3800 nM
The estimate for compound 4 lay 13-fold (1.12 log units) above the measured number; the measured number lies below the stated range.
By their numbers in this assay, from the lowest: compounds 4 and 1 (each within the scatter of the next); then compound 3.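

With no number for compound 2 in this assay, the step to compound 4, at 3800 nM, cannot be read. Nothing shown bears on this result. The compounds shown leave open how carbamoyl and methanesulfonamido compare on the shared core.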